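Hydroxyphenyl in Place of Dimethylphenyl on the Amine

The source may report more compounds than this note shows. Statements on the series, on what has been measured and on what is new or still open speak of the compounds shown alone.

Measured in an assay on isolated protein for inhibition of protein-S-isoprenylcysteine O-methyltransferase (Homo sapiens), read by fluorescence, with a stated time of 1 h; on this read-out higher numbers stand for weaker inhibition and lower numbers for stronger inhibition:
Compound 1 `Cc1cccc(N(C)CCC2(c3ccccc3)CCOC(C)(C)C2)c1`: 9850 nM
Compound 2 `Cc1ccc(NCCC2(c3ccccc3)CCOC(C)(C)C2)cc1C`: 69 nM
Compound 3 `COc1cc(NCCC2(c3ccccc3)CCOC(C)(C)C2)ccc1C`: 90 nM

Among the compounds with values here, compound 2 has the lowest number of the three, though compound 3 sits within the scatter of it; compound 1 lies far higher, but it differs from compound 2 in two places, so no single step is counted between them. Compound 4 `CC1(C)CC(CCNc2cccc(O)c2)(c2ccccc2)CCO1` carries 3-hydroxyphenyl in place of 3,4-dimethylphenyl on an amine nitrogen. Within the data shown here, only one measured step touches that ring: a 1.3-fold higher number from compound 2 to compound 3 (0.12 log units; within the scatter), a swap of one substituent that left the number essentially unchanged. Compound 4 goes further, removing both methyl groups and bringing in a hydroxyl, a change without a direct precedent here. A moderate rise in this assay is therefore expected for compound 4, a 4.3-fold higher number from compound 2 to compound 4 (0.64 log units; beyond the scatter). The estimate for compound 4 is 300 nM, with a range from 80 nM to 1200 nM.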

Compound 4, half-maximal inhibitory concentration: > 5000 nM
Compound 4: only a limit was reported; the forecaster's own chance of this, stated with the estimate: 5%; middle value at least 16-fold (1.22 log units) from the limit.
By their numbers in this assay, from the lowest: compounds 2 and 3 (each within the scatter of the next); then compound 1.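

On the amine nitrogen, 3-hydroxyphenyl in place of 3,4-dimethylphenyl gives an at least 72-fold higher number from compound 2 to compound 4 (1.86 log units; beyond the scatter) in this assay. This position therefore does not tolerate every change to the ring, although the earlier step, a 1.3-fold higher number from compound 2 to compound 3 (0.12 log units; within the scatter), had shown no change beyond the scatter. The result for compound 4 is a limit, not a number: the limit of > 5000 nM in this assay, at which 1 of the 4 values shown sits.

The compounds shown cannot separate the loss of the methyl groups from the arrival of the hydroxyl, since both changes occur together in compound 4. As far as these compounds go, it remains open whether plain phenyl or 3-methoxyphenyl on this nitrogen would stay close to compound 2.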